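Sulfoxide chromones: trading an isobutyl ether for a phenol

The source may report more compounds than this note shows. Statements on the series, on what has been measured and on what is new or still open speak of the compounds shown alone.

Compound 1, `COc1cccc2c(=O)cc(/C=C/[S+](C)[O-])oc12`: 2200 nM
Compound 2, `Cc1c(/C=C/[S+](C)[O-])oc2ccccc2c1=O`: 1500 nM
Compound 3, `CC(C)COc1ccc2oc(/C=C/[S+](C)[O-])cc(=O)c2c1`: 1100 nM

Of the compounds shown here, three sharing the same core have been tested in a functional assay on A549 cells (Homo sapiens) for cytotoxicity, with a stated time of 48 h; on this read-out higher numbers stand for weaker inhibition and lower numbers for stronger inhibition. In this assay compound 1 gives 2200 nM, compound 2 gives 1500 nM and compound 3 gives 1100 nM. Compound 3 returns the smallest of the three numbers, but its gaps to compound 2 and to compound 1 both sit within the usual scatter, so the three cannot be told apart on these data.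

The next compound is compound 4, `C[S+]([O-])/C=C/c1cc(=O)c2cc(O)ccc2o1`, which has not yet been measured in this assay. It differs from compound 3 in one place: hydrogen in place of isobutyl on an oxygen on an aromatic ring. Among the measured compounds shown here, no measured pair shows this change, so there is no step to lean on. The change is expected to shift the number toward weaker inhibition, by a step of a 2.7-fold higher number from compound 3 to compound 4 (0.44 log units; beyond the scatter), somewhat beyond the scatter. Compound 4 is therefore estimated at 3000 nM, with a likely range from 1200 nM to 8000 nM.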

Compound 4, half-maximal inhibitory concentration: 10500 nM
Compound 4: the middle estimate sits 3.5-fold (0.54 log units) below what was measured; measured number outside the range, above it.
By their numbers in this assay, from the lowest: compounds 3, 2 and 1 (each within the scatter of the next); then compound 4.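

Taking off the isobutyl group to leave a hydroxy gives a 9.5-fold higher number from compound 3 to compound 4 (0.98 log units; beyond the scatter) in this assay, the only step here that can be read across a single change. It lies beyond the scatter and moves toward weaker inhibition. This shows what the earlier numbers could not: the group on this oxygen on an aromatic ring matters for the read-out, and isobutoxy reads clearly better than hydroxy. The data shown give no reason for this shift.

Only these two ends of the change are shown, so it stays open whether the step follows the loss of the chain or the presence of the free hydroxy, and an ethoxy on this oxygen would sit between them. From the compounds shown here alone, how an amine or a longer chain in this place would read also remains open.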